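A nitrophenyl replaces a bromophenyl on the ring nitrogen

A few compounds are considered here, and "the series" means these few. Any claim that something is new, unique, unknown or untested is made for them only; others in the source may bear on it.

Compound 2, `N#CC1=C(N)Oc2c(c3nc4ccccc4nc3c3ccccc23)C12C(=O)N(Cc1cnnn1-c1ccccc1Br)c1ccccc12`, was tested in a functional assay on HCT-116 cells (Homo sapiens) for antiproliferative activity, read by MTT assay, with a stated time of 48 h (on this read-out higher numbers stand for weaker inhibition and lower numbers for stronger inhibition), where compound 2 gives > 50000 nM, which is a limit of the assay rather than a measured number. Compound 1, `Cc1cccc(-n2nncc2CN2C(=O)C3(C(C#N)=C(N)Oc4c3c3nc5ccccc5nc3c3ccccc43)c3ccccc32)c1`, differs from compound 2 only in the group on the same aromatic nitrogen. In this assay compound 1 gives > 50000 nM, again a limit. The step that the two limits leave unreadable from compound 1 to compound 2 stays hidden because both values sit at the limit of > 50000 nM in this assay, at which 2 of the 2 values shown sit. Compound 3, `N#CC1=C(N)Oc2c(c3nc4ccccc4nc3c3ccccc23)C12C(=O)N(Cc1cnnn1-c1ccc([N+](=O)[O-])cc1)c1ccccc12`, carries the change (4-nitrophenyl in place of 2-bromophenyl on an aromatic nitrogen). Among the measured compounds shown here, only the step from compound 1 to compound 2 bears on this change, and its size cannot be read, so no step beyond the scatter can be predicted in this assay in either direction, and the most likely outcome is that compound 3 also reaches only the limit. Compound 3 is therefore expected at 50000 nM, within 20000 nM to 120000 nM, an expected step of a number no higher from compound 2 to compound 3 (the limit leaves the size open).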

Compound 3, half-maximal inhibitory concentration: > 50000 nM
Compound 3: only a limit was reported (the forecaster's own chance of this, stated with the estimate: 75%); the middle value lies on the limit itself.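

Among the compounds shown here, compound 1, compound 2 and compound 3 all stop at a limit, so no step between them can be read in this assay: the limit of > 50000 nM in this assay, at which 3 of the 3 values shown sit. The compounds shown leave open whether any group on this aromatic nitrogen would give a true measured number.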